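The source may hold more compounds than are shown below. What is called first, only, known or untested is meant among the compounds shown, and "the series" means these compounds.

Compound 2, `COc1cc2nc(/C=C/c3ccccn3)nc(N3CCC(CCNS(N)(=O)=O)CC3)c2cc1OC`, stands second highest of the three measured compounds in an assay on cells for inhibition of Ectonucleotide pyrophosphatase/phosphodiesterase family member 1 (Homo sapiens), with a stated time of 60 min, tested at 1 uM (a higher number here means more inhibition at the concentration tested (going by the name of the read-out), a lower number less inhibition), where compound 2 gives 85%. Compound 3, `COc1cc2nc(/C=C/c3cccnc3)nc(N3CCC(CCNS(N)(=O)=O)CC3)c2cc1OC`, gives 86%, and the step of a number 1 percentage points higher from compound 2 to compound 3 (within the scatter). Compound 1, `COc1cc2nc(/C=C/c3ccccc3)nc(N3CCC(CCNS(N)(=O)=O)CC3)c2cc1OC`, gives 33%; the steps of a number 52 percentage points higher from compound 1 to compound 2 (beyond the scatter) and a number 53 percentage points higher from compound 1 to compound 3 (beyond the scatter) show that a pyridinyl ring in place of phenyl raised the read-out strongly, with no difference between the two pyridinyl positions.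

Compound 4 is `COc1cc2nc(/C=C/c3cccc(F)c3)nc(N3CCC(CCNS(N)(=O)=O)CC3)c2cc1OC`. The change from compound 2: 3-fluorophenyl in place of pyridin-2-yl on a double-bonded chain carbon bound to a double-bonded chain carbon. Among the compounds with values here, no fluorophenyl analogue has been measured, so the only bearing step is the reverse of the large gain from compound 1 to compound 2. A return to a carbon-only ring is therefore expected to lower the read-out, estimated at a number 40 percentage points lower from compound 2 to compound 4 (beyond the scatter). Compound 4 is expected to give 45%, within 25% to 70%.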

Compound 4, a percentage reported as inhibition, at one concentration (the size of the read-out at that concentration, not a potency): 14%
Compound 4: middle estimate off by 31 percentage points, on the high side, and the stated range ends above it.
By their numbers in this assay, from the lowest: compound 4; then compound 1; then compounds 2 and 3 (each within the scatter of the next).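

In this assay a carbon-only ring again falls far short of both pyridinyl rings, with a number 71 percentage points lower from compound 2 to compound 4 (beyond the scatter) and a number 72 percentage points lower from compound 3 to compound 4 (beyond the scatter) in the step to 3-fluorophenyl. New here is that a substituent on the phenyl ring itself moves the read-out: fluoro in place of hydrogen gives a number 19 percentage points lower from compound 1 to compound 4 (beyond the scatter) and so does not restore what the pyridinyl compounds show. No measured evidence accounts for these steps.

Open, on these data alone, is whether fluoro on a pyridinyl ring would keep the high read-out. Also open, as far as these compounds go, is whether an amine or a methoxy group on the phenyl ring would raise the number or lower it.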